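Replacing the pyridyl ring with benzothiazole: expected cytotoxicity

The compounds below may be only part of what the source reports. "The series", "measured", "known", "first", "only" and "open" are said of these compounds alone.

Measured so far:
compound 1 `Nc1cc2c(=O)c(C(=O)O)cn(C3CC3)c2cc1N1CCN(c2ccccn2)CC1`, 431000 nM
compound 2 `Cn1cc(C(=O)O)c(=O)c2cc(N)c(N3CCN(c4ccccn4)CC3)cc21`, 54000 nM

In an ADME assay on HFF cells (Homo sapiens) for cytotoxicity, read by MTT assay, with a stated time of 5 days (a lower number here means that less compound is tolerated, a higher number that more compound is tolerated), compound 1 gives 431000 nM, the highest of the two numbers. Compound 2 gives 54000 nM in this assay. Among the compounds with values here, the single measured step, an 8.0-fold lower number from compound 1 to compound 2 (0.90 log units; beyond the scatter), concerns the group on the aromatic nitrogen of the shared core and does not touch the ring attached to the six-membered non-aromatic ring with two nitrogens.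

Compound 3 `Nc1cc2c(=O)c(C(=O)O)cn(C3CC3)c2cc1N1CCN(c2nc3ccccc3s2)CC1` differs from compound 1 by 1,3-benzothiazol-2-yl in place of pyridin-2-yl on an amine nitrogen in a ring. Within the data shown here, no measured step bears on this change, so the expectation rests on the value of compound 1 alone, with a wide range to allow for the new, larger group. A modest move toward a lower number is expected, a 2.4-fold lower number from compound 1 to compound 3 (0.38 log units; beyond the scatter), although a result within the scatter of compound 1 would not be surprising. Compound 3 is therefore estimated at 180000 nM, with a range from 50000 nM to 500000 nM.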

Compound 3, half-maximal cytotoxic concentration: 4500 nM
Compound 3: middle estimate off by 40-fold (1.60 log units), on the high side; the whole stated range lies above it.
By their numbers in this assay, from the lowest: compound 3; then compound 2; then compound 1.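

The group on the amine nitrogen in the ring turns out to be a sensitive place in this assay. Putting 1,3-benzothiazol-2-yl in place of pyridin-2-yl gives a 96-fold lower number from compound 1 to compound 3 (1.98 log units; beyond the scatter), so much less compound is tolerated, and this step is larger than the one at the aromatic nitrogen, an 8.0-fold lower number from compound 1 to compound 2 (0.90 log units; beyond the scatter). Nothing available explains why this swap has such a large effect.

As far as these compounds go, it remains open whether the drop follows the sulfur-containing five-membered ring or the added carbon-only six-membered ring; quinolin-2-yl, which has a second six-membered ring but no sulfur, and 1,3-benzoxazol-2-yl, which has oxygen in place of sulfur, could help separate the two. Also open, from the compounds shown here alone, is whether the same swap would have a similar effect with methyl on the aromatic nitrogen, as in compound 2.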